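The source may hold more compounds than are shown below. What is called first, only, known or untested is meant among the compounds shown, and "the series" means these compounds.

compound 1 `Clc1ccc(Nc2nc(Nc3cn[nH]c3)ncc2Cl)cc1` gives 2570 nM 
compound 2 `Clc1cnc(Nc2cn[nH]c2)nc1Nc1ccccc1` gives 5380 nM 

For the measured compounds named here, both values come from a functional assay on PC-3 cells (Homo sapiens) for antiproliferative activity, read by MTT assay, with a stated time of 48 h (on this read-out higher numbers stand for weaker inhibition and lower numbers for stronger inhibition), and are the only measurements so far. Of the two, compound 2 has the higher number, 5380 nM here, so it is the weaker inhibitor of the pair.

Compound 3 `COc1ccc(Nc2nc(Nc3cn[nH]c3)ncc2Cl)cc1` is still unmeasured. It departs from compound 2 by one change, (methoxy in place of hydrogen on an aromatic carbon), which is methoxy in place of hydrogen on an aromatic carbon. This is the carbon that carries the chloro in compound 1.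

Going by the values given here, the one measured step that bears on this change is a 2.1-fold higher number from compound 1 to compound 2 (0.32 log units; beyond the scatter), a modest step at the same carbon. Among the compounds with values here, it shows that a group other than hydrogen at this carbon can go with a lower number, but chloro and methoxy are different groups, and no methoxy compound has yet been measured. Only a small move towards a lower number is therefore expected, and the evidence for it is thin. The expected change is a 1.5-fold lower number from compound 2 to compound 3 (0.19 log units; within the scatter) for this modest reason. For compound 3 the estimated value is 3500 nM, with an expected range from 1400 nM to 8500 nM.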

Compound 3, half-maximal inhibitory concentration: 2300 nM
The estimate for compound 3 lay 1.5-fold (0.18 log units) above the measured number; measured number inside the range.
By their numbers in this assay, from the lowest: compounds 3 and 1 (each within the scatter of the next); then compound 2.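

In this assay, the step from hydrogen to methoxy is a 2.3-fold lower number from compound 2 to compound 3 (0.37 log units; beyond the scatter) and lies beyond the scatter, so chloro is no longer the only group shown to go with a lower number than hydrogen on this aromatic carbon. Replacing chloro with methoxy at the same carbon gives a 1.1-fold lower number from compound 1 to compound 3 (0.05 log units; within the scatter) and lies within the scatter, so this assay does not separate the two groups, even though methoxy brings 2 heavy atoms, carbon and oxygen, where chloro stands alone. Nothing among the available data explains how either group relates to the activity of these compounds.

The compounds shown cover only hydrogen, chloro and methoxy at this carbon, so it remains open whether an amine, a carboxylic acid or a longer chain such as butoxy would fit the same picture. They also leave open whether methoxy and chloro would again sit within the scatter of each other at any other carbon of this ring or with any other change to the shared core.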